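Extending the Aryl Ether Chain in a Cyclopropane Hydrazide Series

This account rests on a few compounds, and the source may have more. Where it says the series, first, only, none or still open, it means among the compounds named here.

Compound 2 `COc1ccc(C2CC2C(=O)NNC(=O)c2ccncc2)cc1`, in a functional assay on A549 cells (Homo sapiens) for inhibition, read by MTT assay, with a stated time of 72 h (a lower number here means a stronger inhibitor, a higher number a weaker inhibitor), reaches only the limit > 100000 nM rather than a number. Compound 1 `CCOc1ccc(C2CC2C(=O)NNC(=O)c2ccncc2)cc1`, which carries a methyl on the saturated chain carbon bound to the oxygen on the aromatic ring, gives 43000 nM in this assay. For the measured compounds named here, the step of an at least 2.3-fold higher number from compound 1 to compound 2 (0.36 log units; beyond the scatter) is the only measured comparison, and it runs toward a weaker inhibitor as the chain is shortened, with compound 2 sitting at the limit of > 100000 nM in this assay, at which 1 of the 2 values shown sits.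

Compound 3 `CC(C)=CCOc1ccc(C2CC2C(=O)NNC(=O)c2ccncc2)cc1` differs from compound 2 by 2-methylprop-1-en-1-yl in place of hydrogen on a saturated chain carbon bound to an oxygen on an aromatic ring. The measured step points the opposite way to this change: removing a methyl made the number larger, so adding a 2-methylprop-1-en-1-yl is expected to bring the number down, toward the region that compound 1 already occupies, although the measured step rests on a limit and so gives no firm size for the gain. Compound 3 is therefore estimated at 30000 nM, with a range from 8000 nM to 100000 nM in this assay. That estimate corresponds to an expected step of an at least 3.3-fold lower number from compound 2 to compound 3 (0.52 log units; beyond the scatter).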

Compound 3, half-maximal inhibitory concentration: > 100000 nM
Compound 3 was reported as a limit; the forecaster's own chance of this, stated with the estimate: 25%; middle value at least 3.3-fold (0.52 log units) away from the limit.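

At the saturated chain carbon bound to an oxygen on an aromatic ring, 2-methylprop-1-en-1-yl in place of methyl gives an at least 2.3-fold higher number from compound 1 to compound 3 (0.36 log units; beyond the scatter) in this assay, so the stronger inhibition that came with methyl at this position does not carry over to this branched, unsaturated group. Among the three compounds, the order at this position is therefore not a steady trend with the size of the group: only methyl gives a number, while hydrogen and 2-methylprop-1-en-1-yl both leave the read-out at a limit and not at a number. The step from compound 2 to compound 3 cannot be read, since both values are limits: the limit of > 100000 nM in this assay, at which 2 of the 3 values shown sit.

The compounds shown leave open whether a group of intermediate length at this carbon, such as ethyl or a straight propyl chain, would lower the number further than methyl does or would already return it to the limit. They also leave open whether a chain ending in an amine or a carboxylic acid at the same carbon would give a measurable number in this assay.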